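The source may report more compounds than this note shows. Statements on the series, on what has been measured and on what is new or still open speak of the compounds shown alone.

Three compounds have been measured:

Compound 1, `C=C(Br)C(=O)Nc1ccc(/C=C/C(=O)c2cccc(OC)c2)cc1`, gives 700 nM in a functional assay on HeLa cells (Homo sapiens) for antiproliferative activity, with a stated time of 48 h; on this read-out lower numbers stand for stronger inhibition and higher numbers for weaker inhibition.
Compound 2, `C=C(Br)C(=O)Nc1ccc(/C=C/C(=O)c2cc(OC)c(OC)c(OC)c2)cc1`, gives 1100 nM.
Compound 3, `COc1cccc(C(=O)/C=C/c2ccc(N)cc2)c1`, gives 33000 nM.

Compound 1 and compound 3 share a core and differ in one place: hydrogen in place of (1-bromoethenyl)carbonyl on a nitrogen on an aromatic ring. This change made a step of a 47-fold higher number from compound 1 to compound 3 (1.67 log units; beyond the scatter), so the compound without the group inhibits the cells far more weakly. Compound 2 carries the same (1-bromoethenyl)carbonyl group on the nitrogen as compound 1, but sits on a different core; the difference between the two cores is not broken down here. The values of compound 2 and compound 1 lie within the scatter of each other, so nothing separates them.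

Compound 4, `COc1cc(C(=O)/C=C/c2ccc(N)cc2)cc(OC)c1OC`, has not been measured. It differs from compound 2 in one place: hydrogen in place of (1-bromoethenyl)carbonyl on a nitrogen on an aromatic ring. The place is the same word for word as in the pair of compound 1 and compound 3, so this is the same change, now made on the core of compound 2. The step from compound 2 to compound 4 in this assay is expected to be a 45-fold higher number from compound 2 to compound 4 (1.66 log units; beyond the scatter), close to the earlier step, because a 47-fold higher number from compound 1 to compound 3 (1.67 log units; beyond the scatter) was seen with the same change on a closely related core. Compound 4 is therefore expected to give about 50000 nM. For compound 4 the expected range runs from 15000 nM to 150000 nM.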

Compound 4, half-maximal inhibitory concentration: 1900 nM
Estimate against measurement, compound 4: 26-fold (1.42 log units) above; measured number below the stated range.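

On the core of compound 2, putting hydrogen in place of (1-bromoethenyl)carbonyl on the nitrogen gives, in this assay, a 1.7-fold higher number from compound 2 to compound 4 (0.24 log units; within the scatter), so the group makes no readable difference on this core. Among the compounds shown here, the same change therefore does not carry over with the same size from one core to another, since it matters greatly on the core of compound 1 but not on the core of compound 2: the same change on two cores in this assay, a 47-fold higher number (1.67 log units; beyond the scatter) from compound 1 to compound 3 and a 1.7-fold higher number (0.24 log units; within the scatter) from compound 2 to compound 4, 27-fold (1.44 log units) apart, beyond the scatter of two such steps This does not show why the two cores respond so differently, and with only one pair on each core it offers no rule for predicting the step on any further core.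

The compounds shown leave open how other groups on the nitrogen would behave on each core, for instance whether a plain acetyl or a chloroacetyl group would track hydrogen or (1-bromoethenyl)carbonyl. They also leave open which feature of the two cores governs the size of the step, for instance whether a core bearing two methoxy groups would follow the core of compound 1 or the core of compound 2.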